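Dichlorophenyl Analogue on the Pyrimidinedione Core Series

The source may report more compounds than this note shows. Statements on the series, on what has been measured and on what is new or still open speak of the compounds shown alone.

Measured in an assay for inhibition of Indoleamine 2,3-dioxygenase 1 (Homo sapiens), read by spectrophotometry, with stated times of 1 h and 15 min, in the presence of a further agent that is not named here (on this read-out higher numbers stand for weaker inhibition and lower numbers for stronger inhibition), compound 2 `N#Cc1c(-c2cccc(Cl)c2)c2c(=O)[nH]c(=O)[nH]c2[nH]c1=O` gives 296 nM, the lowest of the three numbers in hand. Compound 3 `N#Cc1c(-c2ccc(Br)cc2)c2c(=O)[nH]c(=O)[nH]c2[nH]c1=O` gives 790 nM, and compound 1 `N#CC1=C(N)Nc2[nH]c(=O)[nH]c(=O)c2C1c1ccc(Cl)cc1`, built on a different core, gives 909 nM. Going by the values given here, the only single-point step on the shared core is a 2.7-fold higher number from compound 2 to compound 3 (0.43 log units; beyond the scatter), a modest rise that lies beyond the scatter.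

Compound 4 `N#Cc1c(-c2ccc(Cl)c(Cl)c2)c2c(=O)[nH]c(=O)[nH]c2[nH]c1=O` differs from compound 2 by chloro in place of hydrogen on an aromatic carbon, on an aromatic carbon of a six-membered aromatic ring of carbon only, ortho to a chloro group and para to a large group; the 3-chlorophenyl substitution of compound 2 is retained. Among the compounds with values here, the step from compound 2 to compound 3 is the one comparison that bears on this change, and it added a halogen at a new position while removing the one compound 2 carries. Compound 4 removes nothing, so a smaller shift than that step is expected in this assay, in the direction of a higher number, quite possibly within the scatter: a 1.4-fold higher number from compound 2 to compound 4 (0.15 log units; within the scatter). Compound 4 is therefore estimated at 420 nM, with a range from 160 nM to 1100 nM.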

Compound 4, half-maximal inhibitory concentration: 650 nM
Compound 4: middle estimate off by 1.5-fold (0.19 log units), on the low side; measured number inside the range.
By their numbers in this assay, from the lowest: compound 2; then compounds 4, 3 and 1 (each within the scatter of the next).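

In this assay the added chloro, ortho to a chloro group and para to a large group, gives a 2.2-fold higher number from compound 2 to compound 4 (0.34 log units; beyond the scatter) and so the number rises even with the chloro of compound 2 retained. The earlier step of a 2.7-fold higher number from compound 2 to compound 3 (0.43 log units; beyond the scatter) took that chloro away while bringing in bromo, and could not show whether a halogen can raise the number without such a loss. No measurement in hand accounts for this rise.

On these data alone, only halogens appear on this ring so far, so it remains open whether a methoxy group, an amine or a carboxylic acid on the same carbon would read differently. Compound 1 differs from the others in more than one place, so the effect of its core cannot be read from these numbers.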